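The source may hold more compounds than are shown below. What is called first, only, known or untested is meant among the compounds shown, and "the series" means these compounds.

Compound 1 `Nc1c(C(=O)N/N=C/c2ccccc2)oc2nc(-c3cccs3)cc(C(F)(F)F)c12`: 72000 nM
Compound 2 `Nc1c(C(=O)N/N=C/c2ccc(Cl)cc2)oc2nc(-c3cccs3)cc(C(F)(F)F)c12`: 83000 nM
Compound 3 `Nc1c(C(=O)NC2CCCC2)oc2nc(-c3cccs3)cc(C(F)(F)F)c12`: 51000 nM

In an ADME assay on HEK293 cells (Homo sapiens) for antiproliferative activity, read by MTT assay (a higher number here means a weaker inhibitor, a lower number a stronger inhibitor), compound 3 gives 51000 nM, and the numbers do not separate it from the other two compounds. The measured steps are a 1.4-fold lower number from compound 1 to compound 3 (0.15 log units; within the scatter) and a 1.6-fold lower number from compound 2 to compound 3 (0.21 log units; within the scatter), and both stay within the scatter, as does a 1.2-fold higher number from compound 1 to compound 2 (0.06 log units; within the scatter).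

Compound 4 `CCCNC(=O)c1oc2nc(-c3cccs3)cc(C(F)(F)F)c2c1N` keeps the shared core and changes only the group on the amide: propyl in place of cyclopentyl on an amide-type nitrogen. In words, this is propyl in place of cyclopentyl on an amide-type nitrogen.

Among the compounds with values here, no measured step makes this exact exchange, and no measured compound carries an open-chain group there. The closest evidence is the pair of steps to compound 3, which also change the group on that nitrogen. There, a cyclopentyl replaces a group with a six-membered aromatic ring, and neither step leaves the scatter. Three compounds are a thin basis, but they give no reason to expect a real shift in this assay, in either direction. The expected change is a 1.1-fold higher number from compound 3 to compound 4 (0.06 log units; within the scatter), which would be no step beyond the scatter. Compound 4 is estimated at 58000 nM, with an expected range from 32000 nM to 100000 nM.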

Compound 4, half-maximal inhibitory concentration: 64000 nM
Beside the measured number, compound 4's estimate is 1.1-fold (0.04 log units) below it, within the range that was stated.
By their numbers in this assay, from the lowest: compounds 3, 4, 1 and 2 (each within the scatter of the next).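

With compound 4, an open-chain group stands on the amide-type nitrogen for the first time among the compounds shown, and in this assay the exchange of cyclopentyl for propyl stays within the scatter (a 1.3-fold higher number from compound 3 to compound 4 (0.10 log units; within the scatter)). The steps to compound 4 from the two compounds whose group on that nitrogen carries a six-membered aromatic ring also stay within the scatter (a 1.3-fold lower number from compound 2 to compound 4 (0.11 log units; within the scatter); a 1.1-fold lower number from compound 1 to compound 4 (0.05 log units; within the scatter)), so the open chain, like cyclopentyl, is not separated from those groups in this assay, and the four compounds show no measurable preference at this position. No measurement is available that bears on why these numbers lie so close together.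

On these data alone, it remains open whether any group on this nitrogen can produce a step beyond the scatter, for instance a much longer chain such as octyl, or a chain ending in an amine or a carboxylic acid. The trifluoromethyl group is present in all four compounds, so these compounds say nothing about a nitrile or a hydrogen in its place.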